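Series notes: head-group swap on the low-lipophilicity member

The compounds below may be only part of what the source reports. "The series", "measured", "known", "first", "only" and "open" are said of these compounds alone.

The three measured compounds share a core and differ at two places. Compound 1 `CC(C)n1cc(-c2ccnc3[nH]c(C4CCN(CC(=O)N(C)C)CC4)cc23)cnc1=O` gives 0.4 in a physicochemical assay for lipophilicity, using the shake flask method, measured as octanol-water partition, at pH 7.4 (on this read-out higher numbers stand for higher lipophilicity and lower numbers for lower lipophilicity), the lowest of the three numbers, with compound 3 `CC(C)n1cc(-c2ccnc3[nH]c(C4CCN(CC(=O)N5CCCCC5)CC4)cc23)ccc1=O` at 2.8 nearest and compound 2 `CC(C)n1cc(-c2ccnc3[nH]c(C4CCN(Cc5cccs5)CC4)cc23)ccc1=O` at 3.4 furthest. Among the measured compounds shown here, the one single-point step available, a number 0.60 log units lower from compound 2 to compound 3 (beyond the scatter), concerns the group on the saturated chain carbon bound to the ring amine nitrogen; it does not touch the change now considered.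

Compound 4 `CN(C)C(=O)CN1CCC(c2cc3c(-c4ccc(=O)n(C)c4)ccnc3[nH]2)CC1` keeps the side chain of compound 1 and alters the other end: a group of 8 heavy atoms (6 carbon, 1 nitrogen, 1 oxygen; one six-membered aromatic ring with 1 hetero atom) in place of a group of 10 heavy atoms (7 carbon, 2 nitrogen, 1 oxygen; one six-membered aromatic ring with 2 hetero atoms), on an aromatic carbon. For the measured compounds named here, no measured pair covers this exchange, so the expectation rests on compound 1 alone. A group of 8 heavy atoms with one hetero atom in its ring replaces one of 10 heavy atoms with two, and the shorter group and the ring with fewer hetero atoms are expected to pull in opposite directions, so the estimated step of a number 0.10 log units lower from compound 1 to compound 4 (within the scatter) is expected to stay within the scatter. Compound 4 is thus estimated at 0.3, in the range -0.4 to 1.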

Compound 4, distribution coefficient: 1.1
Estimate against measurement, compound 4: 0.80 log units below; measured number above the stated range.
By their numbers in this assay, from the lowest: compound 1; then compound 4; then compound 3; then compound 2.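

In this assay, among the compounds shown here, the exchange on this aromatic carbon, opposite the ring nitrogen, gives a number 0.70 log units higher from compound 1 to compound 4 (beyond the scatter) and is the first change at this end of the molecule that can be read. With the side chain held as in compound 1, the position is therefore not silent on this read-out, and the entering group, the smaller of the two by heavy atoms and with one hetero atom in its ring, goes with the higher number. Nothing at hand bears on the reason for this step.

The two groups differ in heavy atoms and in ring hetero atoms at once, and the compounds shown do not divide the step between these differences. Also open, on these data alone, are whether the step carries over to the thiophen-2-yl and (piperidin-1-yl)carbonyl side chains, and how a phenyl ring or a carboxylic acid on this aromatic carbon would read.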